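From Cyclohexyl to Cycloheptyl on the Shared Core

The source may hold more compounds than are shown below. What is called first, only, known or untested is meant among the compounds shown, and "the series" means these compounds.

In a functional assay on MCF7 cells (Homo sapiens) for inhibition, read by sulforhodamine B assay, with a stated time of 48 h (a lower number here means a stronger inhibitor of growth, a higher number a weaker inhibitor of growth), compound 1 (`O=C(CCl)NC(=O)Nc1ccc(OC2CCCC2)cc1`) gives 3900 nM and compound 2 (`O=C(CCl)NC(=O)Nc1ccc(OC2CCCCC2)cc1`) gives 4700 nM. Compound 2 therefore stands level with compound 1 within the scatter. Compound 3 (`O=C(CCl)NC(=O)Nc1ccc(OC2CCCCCC2)cc1`) carries cycloheptyl in place of cyclohexyl on an oxygen on an aromatic ring. Going by the values given here, only one measured step bears on this change, the swap of cyclopentyl for cyclohexyl, a 1.2-fold higher number from compound 1 to compound 2 (0.08 log units; within the scatter). With that step inside the scatter, no shift beyond the scatter is expected in this assay, and the expected change is a 1.1-fold higher number from compound 2 to compound 3 (0.04 log units; within the scatter). For compound 3 the estimated value is 5200 nM, with an expected range of 2600 nM to 10000 nM.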

Compound 3, concentration for 50% growth inhibition: 3600 nM
Compound 3: middle estimate off by 1.4-fold (0.16 log units), on the high side, and the stated range covers the measured number.
By their numbers in this assay, from the lowest: compounds 3, 1 and 2 (each within the scatter of the next).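

Across cyclopentyl, cyclohexyl and cycloheptyl on an oxygen on an aromatic ring, this assay gives two new steps, a 1.3-fold lower number from compound 2 to compound 3 (0.12 log units; within the scatter) and a 1.1-fold lower number from compound 1 to compound 3 (0.03 log units; within the scatter) and both lie within the scatter. The seven-membered ring therefore extends the level set, and ring size does not separate compound 1, compound 2 and compound 3 in this series. Nothing measured here offers an explanation for this flat result. Still open, from the compounds shown here alone, is whether a phenyl ring, an amine or a longer chain at this place would give a number beyond the scatter.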